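Restoring the amine hydrogen on a biaryl benzylamine

The compounds below may be only part of what the source reports. "The series", "measured", "known", "first", "only" and "open" are said of these compounds alone.

Two measured compounds share one core and differ only at the amine nitrogen. Compound 1 `CNCc1ccc(Cl)c(-c2ccccc2OC)c1` has a hydrogen on that nitrogen, and in a functional assay on HEK293 cells for agonist activity at 5-hydroxytryptamine receptor 7 (Homo sapiens), read by cAMP accumulation, with a stated time of 30 min (on this read-out higher numbers stand for larger maximal responses and lower numbers for smaller maximal responses), compound 1 gives 72%. Compound 2 `COc1ccccc1-c1cc(CN(C)C)ccc1Cl` has a methyl in place of that hydrogen, and in this assay compound 2 gives 11%. For the measured compounds named here, the single change between them is a number 61 percentage points lower from compound 1 to compound 2 (beyond the scatter), so compound 2 stands at the lower of the two numbers, with compound 1 well above it.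

Compound 3 `CCCNCc1ccc(Cl)c(-c2ccccc2OC)c1` has not yet been measured. Compared with compound 2, the change is propylamino in place of dimethylamino on a saturated chain carbon bound to an aromatic carbon. The nitrogen thus carries a hydrogen again, while its carbon chain grows from methyl to propyl. Going by the values given here, the only measured step that bears on this is the one from compound 1 to compound 2, which was large and downward when a methyl replaced the hydrogen. Reversing that change is expected to give back much of the lost response, the step being estimated at a number 49 percentage points higher from compound 2 to compound 3 (beyond the scatter). Whether the longer propyl chain costs anything cannot be judged from two compounds. Compound 3 is therefore expected to give 60%, within a range from 35% to 85%.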

Compound 3, largest response reached (Emax), in percent of the reference or control that the assay uses: 68%
Estimate against measurement, compound 3: 8 percentage points below; the measured number falls inside the stated range.
By their numbers in this assay, from the lowest: compound 2; then compounds 3 and 1 (each within the scatter of the next).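

In this assay, the step of a number 57 percentage points higher from compound 2 to compound 3 (beyond the scatter) shows that the low response of compound 2 is not set by the shared core alone: a large maximal response is seen again once the nitrogen carries a hydrogen, even with propylamino in place of the smaller methylamino of compound 1. The step of a number 4 percentage points lower from compound 1 to compound 3 (within the scatter) adds what the first pair could not show: with a hydrogen on the nitrogen, ethyl in place of hydrogen on a saturated chain carbon bound to an amine nitrogen leaves compound 1 and compound 3 within the scatter of each other, so this read-out does not separate their methyl and propyl chains. No available evidence explains these results.

Still open, on these data alone, is whether this tolerance extends to a longer chain such as butyl or to a ring-bearing group such as cyclopropylmethyl on the nitrogen. It is also unknown how the unsubstituted primary amine would behave, or whether a tertiary amine carrying both propyl and methyl would fall as low as compound 2.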